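Methyl on the shared benzo ring: cytotoxicity notes

The compounds below may be only part of what the source reports. "The series", "measured", "known", "first", "only" and "open" are said of these compounds alone.

Measured in a functional assay on Hs 683 cells (Homo sapiens) for cytotoxicity, read by MTT assay, with a stated time of 72 h; on this read-out lower numbers stand for stronger inhibition and higher numbers for weaker inhibition:
compound 1, `O=C1CC(c2c(-c3ccc[nH]3)[nH]c3ccccc23)C(=O)N1`, 25000 nM
compound 2, `Cc1ccc2[nH]c(-n3cccn3)c(C3=C(Br)C(=O)NC3=O)c2c1`, 29000 nM
compound 3, `O=C1NC(=O)C(c2c(-n3cccn3)[nH]c3ccccc23)=C1Br`, 29000 nM

Compound 2 and compound 3 differ by one change only, (methyl in place of hydrogen on an aromatic carbon). Its step in this assay is no change at the digits printed from compound 3 to compound 2 (within the scatter). The same change is made once more in the series, from compound 1 to compound 4, `Cc1ccc2[nH]c(-c3ccc[nH]3)c(C3CC(=O)NC3=O)c2c1`, which has not yet been measured in this assay: methyl in place of hydrogen on an aromatic carbon. The place of the change is the same in both pairs, word for word, so this is the same change, not merely the same kind. How the core of compound 1 differs from the core of compound 3 is not broken down here; the two values of compound 1 and compound 3 in this assay lie within the scatter of each other, so no order between them is claimed.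

Going by the values given here, with only one measured instance of the change, and that one flat, the expectation for compound 4 rests on the step from compound 3 to compound 2 alone. The step expected from compound 1 to compound 4 in this assay is a 1.1-fold higher number from compound 1 to compound 4 (0.03 log units; within the scatter), beside no change at the digits printed from compound 3 to compound 2 (within the scatter), a flat step because compound 1 gives 25000 nM as the starting point. For compound 4 in this assay the estimate is 27000 nM, expected to lie between 13000 nM and 55000 nM.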

Compound 4, half-maximal inhibitory concentration: 8000 nM
The estimate for compound 4 lay 3.4-fold (0.53 log units) above the measured number, outside the stated range (below it).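

In this assay, methyl in place of hydrogen on an aromatic carbon gives a 3.1-fold lower number from compound 1 to compound 4 (0.49 log units; beyond the scatter), a modest step on the core of compound 1. Set beside the earlier step, the change does not carry over at the same size from one core to the other: the same change on two cores in this assay, no change at the digits printed (within the scatter) from compound 3 to compound 2 and a 3.1-fold lower number (0.49 log units; beyond the scatter) from compound 1 to compound 4, 3.1-fold (0.49 log units) apart, beyond the scatter of two such steps This rests on a single pair on each core and does not show which feature of the cores goes with the gap, nor whether methyl would lower the number on any further core in the series.

The compounds shown leave open whether the step on the core of compound 1 is particular to methyl or would also appear with a longer chain, a methoxy group, an amine or a carboxylic acid at the same place. They also leave open whether a larger group would move the number on the core of compound 3, where methyl gives a flat step.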